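Amino for chloro on the fused core: compound 3

The source may hold more compounds than are shown below. What is called first, only, known or untested is meant among the compounds shown, and "the series" means these compounds.

Measured so far in a functional assay on RPMI8266 cells (Homo sapiens) for antiproliferative activity, read by sulforhodamine B assay, with a stated time of 48 h; on this read-out lower numbers stand for stronger inhibition of growth and higher numbers for weaker inhibition of growth:
compound 1 `Nc1nn(C(=O)Nc2ccc(Cc3ccccc3)cc2)c2ccccc12`, 1860 nM
compound 2 `Nc1nn(C(=O)Nc2ccc(Cc3ccccc3)cc2)c2ccc(Cl)cc12`, 2580 nM

For the measured compounds named here, compound 2 gives the higher of the two numbers seen, but its only neighbour is compound 1, and the step of a 1.4-fold higher number from compound 1 to compound 2 (0.14 log units; within the scatter) lies within the scatter, so the two compounds cannot be told apart on this read-out.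

Compound 3 `Nc1ccc2c(c1)c(N)nn2C(=O)Nc1ccc(Cc2ccccc2)cc1` is not yet measured. It differs from compound 2 by amino in place of chloro on an aromatic carbon. Going by the values given here, the one measured step that touches the same aromatic carbon is a 1.4-fold higher number from compound 1 to compound 2 (0.14 log units; within the scatter), where chloro replaced hydrogen without moving the number beyond the scatter. Among the compounds with values here, no measured step shows an amino group at that position, so the direction of the change is not read from the data. The expectation rests on the observation that this position has so far tolerated a change without a measurable effect.

For compound 3 the estimated step of a 1.3-fold lower number from compound 2 to compound 3 (0.11 log units; within the scatter) is therefore expected to stay within the scatter. Compound 3 is estimated at 2000 nM, with a range from 800 nM to 5000 nM.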

Compound 3, concentration for 50% growth inhibition: 5140 nM
Compound 3: the middle estimate sits 2.6-fold (0.41 log units) below what was measured; measured number above the stated range.
By their numbers in this assay, from the lowest: compounds 1, 2 and 3 (each within the scatter of the next, the first and the last beyond it).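

Working notes on this aromatic carbon: in this assay, amino is the first replacement for hydrogen to give a step beyond the scatter, a 2.8-fold higher number from compound 1 to compound 3 (0.44 log units; beyond the scatter), though this step is modest in size. The comparison with the chloro compound remains unresolved, with a 2.0-fold higher number from compound 2 to compound 3 (0.30 log units; within the scatter) lying within the scatter, so amino and chloro cannot be told apart on this read-out and compound 2 cannot be separated from either of the other two compounds; the position is therefore not wholly insensitive to substitution, but only the hydrogen and amino compounds are separated. No measured evidence bears on the origin of this step.

Still open, on these data alone, is how other groups on this carbon would compare with hydrogen and amino, for example a hydroxyl, a methoxy, an acetylamino or a carboxylic acid group. Also open, as far as these compounds go, is whether amino in place of hydrogen gives a similar step on another aromatic carbon of the same ring, and whether a dimethylamino group would separate from hydrogen as amino does.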